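Working notes: from compound 2 to compound 4

The source may report more compounds than this note shows. Statements on the series, on what has been measured and on what is new or still open speak of the compounds shown alone.

Of the compounds shown here, three have been measured in a physicochemical assay for lipophilicity, read by HPLC, at pH 7.5; on this read-out higher numbers stand for higher lipophilicity and lower numbers for lower lipophilicity. Compound 1 `CCOc1ccccc1-c1ccc(-c2nc(NC(C)C(=O)O)c3ccncc3n2)cc1` gives 2.1. Compound 3 `CC(C)(CC(N)=O)c1c(C#N)c(-c2ccc(Br)cc2)nc2cnccc12` gives 2.1. Compound 2 `CC[C@@H](Nc1c(C#N)c(-c2ccc(-c3cccc(OC)c3)cc2)nc2cnccc12)C(N)=O` gives 2.7, the highest of the three numbers, beyond the scatter above both compound 1 and compound 3, which sit level with each other. Compound 4 `CC[C@@H](Nc1c(C#N)c(-c2ccc(-c3ccccc3Cl)cc2)nc2cnccc12)C(N)=O` has not been measured. It differs from compound 2 as follows: 2-chlorophenyl in place of 3-methoxyphenyl on an aromatic carbon. Going by the values given here, no step between measured compounds covers this kind of change, so the expectation rests on compound 2 at 2.7 alone. The step is estimated as a number 0.50 log units higher from compound 2 to compound 4 (beyond the scatter), modest but beyond the scatter, in the upward direction. Compound 4 is thus estimated at 3.2, within a range from 2.8 to 3.6.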

Compound 4, distribution coefficient: 2.9
For compound 4 the middle estimate is 0.30 log units above the measured one; measured number inside the range.
By their numbers in this assay, from the lowest: compounds 1 and 3 (each within the scatter of the next); then compounds 2 and 4 (each within the scatter of the next).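

In this assay, 2-chlorophenyl in place of 3-methoxyphenyl on this aromatic carbon, para to a large group, gives a number 0.20 log units higher from compound 2 to compound 4 (within the scatter), the first step read at this position. On this read-out the two groups therefore cannot be told apart, even though the hydrogen-bond acceptor of 3-methoxyphenyl is lost and chlorine enters. Nothing available explains this step.

The substituent and its place on the ring change together, so the compounds shown do not separate the two. As far as these compounds go, how a phenyl carrying an aminomethyl group would read at this position remains open.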